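A Formylthiophene Swap on the Shared Core

The source may hold more compounds than are shown below. What is called first, only, known or untested is meant among the compounds shown, and "the series" means these compounds.

Measured in a functional assay on MV4-11 cells (Homo sapiens) for inhibition, read by resazurin assay, with a stated time of 72 h; on this read-out higher numbers stand for weaker inhibition of growth and lower numbers for stronger inhibition of growth:
- compound 1 `Cc1ccc(-c2cncc(Cl)c2N2CCC3(CCNC3=O)CC2)s1`: 650 nM
- compound 2 `O=C1NCCC12CCN(c1c(Cl)cncc1-c1ccc(Cl)s1)CC2`: 560 nM
- compound 3 `CC(=O)c1ccc(-c2cncc(Cl)c2N2CCC3(CCNC3=O)CC2)s1`: 1440 nM

Compound 3 has the highest number of the three in this assay. Compound 4 `O=Cc1cc(-c2cncc(Cl)c2N2CCC3(CCNC3=O)CC2)cs1` carries 5-formylthiophen-3-yl in place of the 5-acetylthiophen-2-yl of compound 3 (5-formylthiophen-3-yl in place of 5-acetylthiophen-2-yl on an aromatic carbon). The nearest evidence is a 2.2-fold higher number from compound 1 to compound 3 (0.35 log units; beyond the scatter) and a 2.6-fold higher number from compound 2 to compound 3 (0.41 log units; beyond the scatter), whereas a 1.2-fold lower number from compound 1 to compound 2 (0.06 log units; within the scatter) shows that the other two groups differ little. Within the data shown here, no measured compound carries the 5-formylthiophen-3-yl group, so these steps only suggest the likely size. A modest move toward a lower number is expected, namely a 1.6-fold lower number from compound 3 to compound 4 (0.20 log units; within the scatter). Compound 4 is estimated at 900 nM, within an expected range of 350 nM to 2300 nM.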

Compound 4, concentration for 50% growth inhibition: 730 nM
Compound 4: the middle estimate sits 1.2-fold (0.09 log units) above what was measured; the measured number falls inside the stated range.
By their numbers in this assay, from the lowest: compounds 2, 1, 4 and 3 (each within the scatter of the next, the first and the last beyond it).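

In this assay, this position takes the change of 5-acetylthiophen-2-yl to 5-formylthiophen-3-yl with a 2.0-fold lower number from compound 3 to compound 4 (0.30 log units; within the scatter), so this swap does not separate the two compounds. Unlike the acetyl compound, the formyl compound stays level with the chloro and methyl compounds, with a 1.3-fold higher number from compound 2 to compound 4 (0.12 log units; within the scatter) and a 1.1-fold higher number from compound 1 to compound 4 (0.05 log units; within the scatter) as the printed steps. Nothing given here explains this result. The swap alters both the carbonyl substituent and the thiophene attachment, and the compounds shown do not separate these two changes. On these data alone, how an aminomethyl group or a carboxylic acid on the thiophene would read here remains open.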